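Swapping the Aniline Ring: Fluorophenyl to Dimethoxyphenyl

The source may hold more compounds than are shown below. What is called first, only, known or untested is meant among the compounds shown, and "the series" means these compounds.

Measured so far in a functional assay on BT-474 cells (Homo sapiens) for cytotoxicity, read by MTT assay, with a stated time of 48 h; a lower number here means a stronger inhibitor, a higher number a weaker inhibitor:
- compound 1 `O=C(/C=C\Nc1ccc(F)cc1)c1nc(-c2ccc(F)cc2)n2ccccc12` gives 16900 nM
- compound 2 `COc1ccc(-c2nc(C(=O)/C=C\Nc3ccc(Cl)cc3)c3ccccn23)cc1` gives 37300 nM
- compound 3 `O=C(/C=C\Nc1ccc(F)cc1)c1nc(-c2ccc(C(F)(F)F)cc2)n2ccccc12` reaches only the assay limit > 30000 nM

Compound 1 holds the lowest of the two numbers; compound 2 sits higher, beyond the usual scatter, though the two differ in more than one place. For the measured compounds named here, the only single-site step, an at least 1.7-fold higher number from compound 1 to compound 3 (0.24 log units; that floor lies within the scatter), changes an aromatic carbon, and its floor is fixed by the limit of > 30000 nM in this assay, at which 1 of the 3 values shown sits. Compound 4 `COc1ccc(N/C=C\C(=O)c2nc(-c3ccc(F)cc3)n3ccccc23)cc1OC` differs from compound 1 by 3,4-dimethoxyphenyl in place of 4-fluorophenyl on an amine nitrogen. Going by the values given here, no measured step touches the amine nitrogen, so the expectation rests on compound 1 alone. Compound 4 is expected to move by a 1.5-fold higher number from compound 1 to compound 4 (0.17 log units; within the scatter), a step not clearly beyond the scatter. The estimate for compound 4 is 25000 nM, ranging from 10000 nM to 60000 nM.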

Compound 4, half-maximal inhibitory concentration: > 30000 nM
Compound 4: a limit, no number (the forecaster's own chance of this, stated with the estimate: 30%); middle value at least 1.2-fold (0.07 log units) from the limit.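

For the compounds shown here, replacing 4-fluorophenyl with 3,4-dimethoxyphenyl on the amine nitrogen gives the first measured step at this place: an at least 1.7-fold higher number from compound 1 to compound 4 (0.24 log units; that floor lies within the scatter). The change brought no lower number, yet that floor does not establish a real loss. The true size of the step stays unknown because compound 4 reached a limit rather than a number, and the floor is fixed by that limit: the limit of > 30000 nM in this assay, at which 2 of the 4 values shown sit.

Going by these compounds, what a plain alkyl chain or a morpholine ring would do on the amine nitrogen remains open. So does whether any group there can bring the number below that of compound 1.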